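Amide replaced by benzylamine on the side-chain nitrogen

A few compounds are considered here, and "the series" means these few. Any claim that something is new, unique, unknown or untested is made for them only; others in the source may bear on it.

Compound 2 `COc1ccc(Cn2c(C(=O)O)c(CNC(=O)c3cccc(OC)c3)c3ccc(C)cc32)cc1` reports only a limit in a functional assay on Bel-7402 cells (Homo sapiens) for antiproliferative activity, read by MTT assay, with a stated time of 72 h; on this read-out higher numbers stand for weaker inhibition and lower numbers for stronger inhibition: compound 2 sits at > 50000 nM, the position noted as the limit of > 50000 nM in this assay, at which 1 of the 2 values shown sits. Compound 3 `COc1ccc(Cn2c(C(=O)O)c(CNCc3cccc(O)c3)c3ccc(C)cc32)cc1` differs from compound 2 by 3-hydroxybenzyl in place of (3-methoxyphenyl)carbonyl on an amine nitrogen. Within the data shown here, no measured step covers this change directly. Compound 1 `COc1ccc(Cn2c(C(=O)O)c(CNCc3cccc(O)c3)c3ccc(C(C)C)cc32)cc1` carries the same (3-hydroxybenzyl)amino group and gives 9270 nM in this assay, so a step towards stronger inhibition, beyond the usual scatter, is expected for compound 3. Compound 3 is estimated at 12000 nM, within 4000 nM to 40000 nM, which means an expected step of an at least 4.1-fold lower number from compound 2 to compound 3 (0.61 log units; beyond the scatter).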

Compound 3, half-maximal inhibitory concentration: 19800 nM
Compound 3: middle estimate off by 1.7-fold (0.22 log units), on the low side; measured number inside the range.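

In this assay, 3-hydroxybenzyl in place of (3-methoxyphenyl)carbonyl on the amine nitrogen gives an at least 2.5-fold lower number from compound 2 to compound 3 (0.40 log units; beyond the scatter), so this change can now be read directly, though only as a bound. Compound 2 stands at a limit, not a number: the limit of > 50000 nM in this assay, at which 1 of the 3 values shown sits.

With the (3-hydroxybenzyl)amino group held constant, the aromatic-carbon substituent also matters: methyl in place of isopropyl gives a 2.1-fold higher number from compound 1 to compound 3 (0.33 log units; beyond the scatter).

The swap alters the carbonyl and the ring oxygen substituent together, so a 3-methoxybenzyl group on that nitrogen would be needed to separate them. On these data alone, whether ethyl on that aromatic carbon would give a value between those of compound 1 and compound 3 remains open.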